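Secondary versus tertiary amine on the core of compound 3

The source may hold more compounds than are shown below. What is called first, only, known or untested is meant among the compounds shown, and "the series" means these compounds.

compound 1, `COCCNc1nc(C)nc2c1nnn2-c1c(C)cc(C)cc1C`: 1200 nM in an in vitro assay on 293-EBNA cells for binding affinity to corticotropin-releasing factor receptor 1 (Homo sapiens); on this read-out higher numbers stand for weaker inhibition and lower numbers for stronger inhibition
compound 2, `Cc1nc(N2CCCC2)c2nnn(-c3ccc(C(C)C)cc3Br)c2n1`: 194 nM in this assay
compound 3, `CCCCN(CC)c1nc(C)nc2c1ncn2-c1ccc(C(C)C)cc1Br`: 4.3 nM in this assay

Among the three measured compounds, compound 3 holds the lowest number in this assay. Its nearest neighbour is compound 2, whose value sits well above it, beyond the scatter of repeated measurements; compound 1 lies further off still, also beyond the scatter. Compound 3 is thus the strongest binder of the three.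

Compound 4, `CCCC(CCC)Nc1nc(C)nc2c1ncn2-c1ccc(C(C)C)cc1Br`, is the next point on this series. It differs from compound 3 in one place: (1-propylbutyl)amino in place of butyl(ethyl)amino on an aromatic carbon. Within the data shown here, no pair of measured compounds shares this exact change, so nothing measured gives its size directly. The expectation for the step from compound 3 to compound 4 in this assay is a 1.2-fold lower number from compound 3 to compound 4 (0.09 log units; within the scatter), that is, no change beyond the scatter in either direction. On that basis compound 4 is expected to give 3.5 nM in this assay, with a range from 0.8 nM to 15 nM.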

Compound 4, inhibition constant: 3.6 nM
Compound 4: middle estimate off by 1.0-fold (0.01 log units), on the low side; measured number inside the range.
By their numbers in this assay, from the lowest: compounds 4 and 3 (each within the scatter of the next); then compound 2; then compound 1.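

The step from a tertiary amine, butyl(ethyl)amino, to a secondary one, (1-propylbutyl)amino, gives a 1.2-fold lower number from compound 3 to compound 4 (0.08 log units; within the scatter) in this assay, so the two amines cannot be told apart on this read-out. Among these compounds, this aromatic carbon therefore accepts the hydrogen-bond donor of (1-propylbutyl)amino with no shift beyond the scatter, and no earlier pair isolated this change. Nothing available accounts for this equivalence.

From the compounds shown here alone, it remains open whether the equivalence extends to a shorter secondary amine such as propylamino, or to a cyclic amine such as morpholine, at this position. Going by these compounds, it is also open whether (1-propylbutyl)amino and butyl(ethyl)amino would read alike on the core of compound 2, where the same comparison would test whether the equivalence depends on the shared core.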